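Methyl in place of hydrogen on compound 2

This account rests on a few compounds, and the source may have more. Where it says the series, first, only, none or still open, it means among the compounds named here.

In a functional assay on ZR-75-1 cells (Homo sapiens) for inhibition, read by sulforhodamine B assay (on this read-out higher numbers stand for weaker inhibition of growth and lower numbers for stronger inhibition of growth), compound 1 `c1ccc(-c2ccc(-c3ccc(-c4nc5ccccc5[nH]4)cc3)cc2)cc1` gives 100000 nM. Compound 2 `FC(F)(F)Oc1ccc(-c2ccc(-c3ccc(-c4nc5ccccc5[nH]4)cc3)cc2)cc1` gives 100000 nM, level with compound 1. Within the data shown here, the only measured step, trifluoromethoxy in place of hydrogen on an aromatic carbon, shows no change at the digits printed from compound 1 to compound 2 (within the scatter). Compound 3 `Cc1ccc2[nH]c(-c3ccc(-c4ccc(-c5ccc(OC(F)(F)F)cc5)cc4)cc3)nc2c1` carries methyl in place of hydrogen on an aromatic carbon, 1H-benzimidazol-2-yl to 5-methyl-1H-benzimidazol-2-yl: methyl in place of hydrogen on an aromatic carbon. Among the measured compounds shown here, no measured step covers this methyl change, so the evidence is thin, and no shift beyond the scatter is expected in this assay. The expected step is no change at the digits printed from compound 2 to compound 3 (within the scatter). The estimate for compound 3 is 100000 nM, with an expected range from 30000 nM to 130000 nM.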

Compound 3, concentration for 50% growth inhibition: 2410 nM
Compound 3: middle estimate off by 41-fold (1.62 log units), on the high side; measured number below the stated range.
By their numbers in this assay, from the lowest: compound 3; then compounds 1 and 2 (each within the scatter of the next).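

The earlier step in this assay, trifluoromethoxy on the far end of the molecule, gave no change at the digits printed from compound 1 to compound 2 (within the scatter) and so showed no response. Going from 1H-benzimidazol-2-yl to 5-methyl-1H-benzimidazol-2-yl gives a 41-fold lower number from compound 2 to compound 3 (1.62 log units; beyond the scatter), so this aromatic carbon is sensitive to substitution, and a single added carbon is enough to move the number. No measurement here bears on why the step is so large.

On these data alone, whether ethyl, methoxy or an amine on the same carbon keeps the lower number remains open. Also open, as far as these compounds go, is whether methyl has the same effect on compound 1, which lacks the trifluoromethoxy group.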